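Swapping butoxy for methylsulfanyl on a shared core

This account rests on a few compounds, and the source may have more. Where it says the series, first, only, none or still open, it means among the compounds named here.

Compound 3, drawn as `CCCCOc1ccc(/N=c2\ssnc2Cl)cc1`, was tested in a functional assay on A-431 cells (Homo sapiens) for cytotoxicity, read by resazurin assay, with a stated time of 72 h; on this read-out higher numbers stand for weaker inhibition and lower numbers for stronger inhibition. In this assay compound 3 gives > 100000 nM, which is a limit of the assay rather than a number. Two related compounds share the same core and differ from compound 3 only in the group on the aromatic oxygen. Compound 1 `Clc1nss/c1=N\c1ccc(OCc2ccccc2)cc1` in this assay gives > 100000 nM, again a limit. Compound 2 `Clc1nss/c1=N\c1ccc(Oc2ccccc2)cc1` in this assay gives > 100000 nM, also a limit. The steps among these three, a step that the two limits leave unreadable from compound 1 to compound 2, a step that the two limits leave unreadable from compound 1 to compound 3 and a step that the two limits leave unreadable from compound 2 to compound 3, therefore cannot be sized at all. What the measurements have in common is the limit of > 100000 nM in this assay, at which 3 of the 3 values shown sit.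

Compound 4 `CSc1ccc(/N=c2\ssnc2Cl)cc1` differs from compound 3 in one place: methylsulfanyl in place of butoxy on an aromatic carbon. Among the compounds with values here, no measured step bears on this change in a readable way, since every comparison ends at the limit, and the three compounds give no hint that any change at this position moves the read-out. The expected step is a number no higher from compound 3 to compound 4 (the limit leaves the size open), meaning no change beyond the scatter. In this assay compound 4 is expected to give 100000 nM, within a range from 25000 nM to 400000 nM, most likely reported once more as a limit.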

Compound 4, half-maximal inhibitory concentration: 51000 nM
Compound 4: the middle estimate sits 2.0-fold (0.29 log units) above what was measured; low and high end bracket the measured number.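

Within the data shown here, compound 4 is the first compound here to give a readable number in this assay, so this aromatic carbon is a place where a change of group can bring a compound off the limit. The swap of butoxy for methylsulfanyl gives an at least 1.9-fold lower number from compound 3 to compound 4 (0.29 log units; that floor lies within the scatter), and that figure is only a floor: compound 3 has a limit rather than a number, so the true step could be larger, but the data do not establish a change beyond the usual scatter. One readable number is still thin support for any trend, and the other compounds in this small set remain out of range: the limit of > 100000 nM in this assay, at which 3 of the 4 values shown sit.

The compounds shown do not separate the effect of swapping oxygen for sulfur from that of swapping a longer chain for a shorter one, a question that comparisons with methoxy or butylsulfanyl at this position would address. Going by these compounds, how an amine or a carboxylic acid on this carbon would read also stays open, as does whether any group here can bring the number much lower.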